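From 2-phenyl-1H-imidazol-1-yl to 5-methyl-1H-tetrazol-1-yl

The source may report more compounds than this note shows. Statements on the series, on what has been measured and on what is new or still open speak of the compounds shown alone.

Of the compounds shown here, three with a shared core have been tested in a functional assay on HUVEC cells (Homo sapiens), read by scintillation counting and thymidine incorporation, with a stated time of 24 h (a higher number here means a weaker inhibitor, a lower number a stronger inhibitor), so far. Compound 1 `CCC(C)n1ncn(-c2ccc(N3CCN(c4ccc(OC[C@@H]5CO[C@@](CN(C)C)(c6ccc(Cl)cc6Cl)O5)cc4)CC3)cc2)c1=O` gives 1400 nM with dimethylamino on the side chain. Compound 2 `CCC(C)n1ncn(-c2ccc(N3CCN(c4ccc(OC[C@@H]5CO[C@@](Cn6ccnc6C)(c6ccc(Cl)cc6Cl)O5)cc4)CC3)cc2)c1=O` gives 173 nM with 2-methyl-1H-imidazol-1-yl in that place. Compound 3 `CCC(C)n1ncn(-c2ccc(N3CCN(c4ccc(OC[C@@H]5CO[C@@](Cn6ccnc6-c6ccccc6)(c6ccc(Cl)cc6Cl)O5)cc4)CC3)cc2)c1=O` gives 136 nM with 2-phenyl-1H-imidazol-1-yl there. Compound 3 therefore stands level with compound 2 within the scatter, and both lie well under compound 1.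

The next compound is compound 4 `CCC(C)n1ncn(-c2ccc(N3CCN(c4ccc(OC[C@@H]5CO[C@@](Cn6nnnc6C)(c6ccc(Cl)cc6Cl)O5)cc4)CC3)cc2)c1=O`, with 5-methyl-1H-tetrazol-1-yl in place of 2-phenyl-1H-imidazol-1-yl on a saturated chain carbon bound to a saturated ring carbon.

All three measured steps bear on this place. Replacing dimethylamino with an imidazole group gave an 8.1-fold lower number from compound 1 to compound 2 (0.91 log units; beyond the scatter) in one case and a 10-fold lower number from compound 1 to compound 3 (1.01 log units; beyond the scatter) in the other, so this position clearly responds to change. Exchanging methyl for phenyl gave only a 1.3-fold lower number from compound 2 to compound 3 (0.10 log units; within the scatter) and stayed within the scatter, so losing the phenyl gives little reason to expect a large move. Among the measured compounds shown here, no tested compound carries the tetrazole ring, and that leaves real uncertainty, with a slight rise in the number the more likely direction.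

The expected change is a 1.6-fold higher number from compound 3 to compound 4 (0.21 log units; within the scatter) and no larger shift is anticipated. For compound 4 the estimated value is 220 nM with an expected range from 80 nM to 650 nM in this assay.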

Compound 4, half-maximal inhibitory concentration: 101 nM
Compound 4: the middle estimate sits 2.2-fold (0.34 log units) above what was measured, and the stated range covers the measured number.
By their numbers in this assay, from the lowest: compounds 4, 3 and 2 (each within the scatter of the next); then compound 1.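

In this assay, swapping either imidazole group for 5-methyl-1H-tetrazol-1-yl gives a 1.3-fold lower number from compound 3 to compound 4 (0.13 log units; within the scatter) and a 1.7-fold lower number from compound 2 to compound 4 (0.23 log units; within the scatter), so this position accepts a very different ring with no change beyond the scatter, even though the tetrazole has 4 hetero atoms in its five-membered ring and no six-membered aromatic ring. The large difference from dimethylamino also holds for this third ring group, with a 14-fold lower number from compound 1 to compound 4 (1.14 log units; beyond the scatter), so among these four compounds it is not confined to imidazoles. No measurement here explains why such different rings give values within the scatter of each other.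

Among the compounds shown here, compound 1 is the only compound without an aromatic ring at this position, so a single example cannot show whether the difference comes from adding such a ring or from removing dimethylamino. An unsubstituted 1H-imidazol-1-yl or 1H-tetrazol-1-yl group would show whether the ring needs a substituent at all, while a saturated amine such as morpholin-4-yl on the same chain carbon would show whether a ring that is not aromatic can match these values.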